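The source may hold more compounds than are shown below. What is called first, only, known or untested is meant among the compounds shown, and "the series" means these compounds.

Measured so far:
compound 1, `CC(C)(CCCCC(=O)CCCCC(C)(C)C(=O)O)C(=O)O`: 3000 nM
compound 2, `CC(C)(CO)CCCCCC(=O)CCCCCC(C)(C)CO`: 3000 nM

Of the compounds shown here, two have been tested in a functional assay on cells (Hepatocyte, Rattus norvegicus) for inhibition; on this read-out lower numbers stand for stronger inhibition and higher numbers for weaker inhibition. Compound 1 has the structure `CC(C)(CCCCC(=O)CCCCC(C)(C)C(=O)O)C(=O)O` and in this assay compound 1 gives 3000 nM. Compound 2, `CC(C)(CO)CCCCCC(=O)CCCCCC(C)(C)CO`, gives 3000 nM in this assay. Compound 1 therefore stands level with compound 2; the two values lie within the usual scatter of each other, so no order between them can be read from these numbers. Within the data shown here, the two structures differ in several places at once, so no single step can be drawn between them.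

Compound 3, `CC(C)(CCCCC(=O)CCCC(C)(C)C(=O)O)C(=O)O`, has not been measured yet. It is derived from compound 1 by one change: 1-carboxy-1-methylethyl in place of 2-carboxy-2-methylpropyl on a saturated chain carbon, three bonds along the chain from a carbonyl carbon. The rest of the molecule, including the central carbonyl and the second acid-bearing end of the chain, stays as it is in compound 1. Among the measured compounds shown here, with no measured step of this kind to lean on, the expectation is a small change in this assay, in no fixed direction, and probably not beyond the scatter. Compound 3 is therefore estimated at 3000 nM, between 1000 nM and 10000 nM, which would mean an expected step of no change at the digits printed from compound 1 to compound 3 (within the scatter).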

Compound 3, half-maximal inhibitory concentration: 8000 nM
Compound 3: the middle estimate sits 2.7-fold (0.43 log units) below what was measured; measured number inside the range.
By their numbers in this assay, from the lowest: compounds 1 and 2 (each within the scatter of the next); then compound 3.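

Among these compounds, compound 3 supplies the first step in this assay that can be read as a single change: with 1-carboxy-1-methylethyl in place of 2-carboxy-2-methylpropyl, there is a 2.7-fold higher number from compound 1 to compound 3 (0.43 log units; beyond the scatter) and thus weaker inhibition. This shows that the read-out responds to what sits on this saturated chain carbon, three bonds along the chain from a carbonyl carbon, even though the step is modest. The two groups match in their counts of rings, double bonds, hydrogen-bond donors and hydrogen-bond acceptors and differ in heavy atoms, with the entering group having fewer carbons, but a count alone does not explain the result, and no measurement here accounts for the weaker inhibition.

As far as these compounds go, this single step runs in one direction only, so it remains open whether a longer chain at the same place, such as 3-carboxy-3-methylbutyl, would bring a lower number or a still higher one. It is also open whether the end of the chain needs its acid at all, since an amide or a primary amine in that place would test this more directly than the compounds shown can.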